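A Methyl Added on Two Different Cores

The source may hold more compounds than are shown below. What is called first, only, known or untested is meant among the compounds shown, and "the series" means these compounds.

Compound 1, `CCC(C)C1NC(=O)N(C2CCCC2)C1=O`, gives > 100000 nM in a functional assay on HEp-2 cells (Homo sapiens) for inhibition; a lower number here means a stronger inhibitor, a higher number a weaker inhibitor; that value is a limit of the assay, not a number.
Compound 2, `CC(C)C1NC(=O)N(C2CCCC2)C1=O`, gives 98000 nM in this assay.
Compound 3, `CC(C)C(NC(=O)n1nnc2ccccc21)C(=O)NC1CCCC1`, gives 60300 nM in this assay.

Compounds 1 and 2 share one core and differ by a single change, (methyl in place of hydrogen on a saturated chain carbon, two bonds along the chain from a saturated ring carbon). The measured step is an at least 1.0-fold higher number from compound 2 to compound 1 (0.00 log units; that floor lies within the scatter). Compound 1 sits at the limit of > 100000 nM in this assay, at which 1 of the 3 values shown sits. Compound 3 carries a different core; how its core differs from that of compound 2 is not broken down here. Compound 4, `CCC(C)C(NC(=O)n1nnc2ccccc21)C(=O)NC1CCCC1`, is not yet measured. It differs from compound 3 by methyl in place of hydrogen on a saturated chain carbon, three bonds along the chain from an amide-type nitrogen and a carbonyl carbon. This is the same kind of change as in the earlier pair, but not the same: there the methyl enters two bonds along the chain from a saturated ring carbon, while here it enters three bonds along the chain from an amide-type nitrogen and a carbonyl carbon. Because the earlier step of an at least 1.0-fold higher number from compound 2 to compound 1 (0.00 log units; that floor lies within the scatter) stayed within the scatter, a similarly small step is expected here, a 1.2-fold higher number from compound 3 to compound 4 (0.06 log units; within the scatter). Compound 4 is therefore estimated at 70000 nM, with a likely range from 30000 nM to 200000 nM.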

Compound 4, half-maximal inhibitory concentration: 55700 nM
Beside the measured number, compound 4's estimate is 1.3-fold (0.10 log units) above it; the range from low to high includes it.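

On the second core, the swap of isopropyl for sec-butyl gives a 1.1-fold lower number from compound 3 to compound 4 (0.03 log units; within the scatter) in this assay, so adding this methyl makes no difference that can be told from the usual scatter there. The step on the first core can be set beside this one only in part, so the data do not show that the methyl acts alike on both cores, nor do they show that it acts differently: the same change on two cores in this assay, an at least 1.0-fold higher number (0.00 log units; that floor lies within the scatter) from compound 2 to compound 1 and a 1.1-fold lower number (0.03 log units; within the scatter) from compound 3 to compound 4; the limit leaves it open whether they differ The open point lies with compound 1, whose value is a limit of the assay and not a number: the limit of > 100000 nM in this assay, at which 1 of the 4 values shown sits.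

The compounds shown leave open how large the step on the first core really is. They also leave open whether a longer chain, or a chain carrying an amine or a carboxylic acid, in place of the isopropyl would shift the number beyond the scatter on either core.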